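Fluorine on the hydrazone phenyl of a triazole thioether

The compounds below may be only part of what the source reports. "The series", "measured", "known", "first", "only" and "open" are said of these compounds alone.

Measured compounds:
compound 1 `Brc1cccc(CSc2nnc(-c3ccncc3)n2-c2ccccc2)c1`: 10000 nM
compound 2 `Clc1ccc(CSc2nnc(-c3ccncc3)n2-c2ccccc2)cc1`: 13300 nM
compound 3 `O=C(CSc1nnc(-c2ccncc2)n1-c1ccccc1)N/N=C/c1ccccc1`: 23600 nM

In a functional assay on MCF7 cells (Homo sapiens) for inhibition, read by MTT assay, with a stated time of 48 h (a higher number here means a weaker inhibitor, a lower number a stronger inhibitor), compound 1 gives 10000 nM and compound 2 gives 13300 nM; the step of a 1.3-fold higher number from compound 1 to compound 2 (0.12 log units; within the scatter) lies within the scatter. Compound 3 gives 23600 nM in this assay, a number within the scatter of that of compound 2 but higher than that of compound 1 by more than the scatter.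

Compound 4 `O=C(CSc1nnc(-c2ccncc2)n1-c1ccccc1)N/N=C/c1ccccc1F` has not yet been measured. It differs from compound 3 by fluoro in place of hydrogen on an aromatic carbon. No measured step touches this part of the molecule: the only step shown, from compound 1 to compound 2, swaps halogenated phenyl groups on the chain carbon next to the sulfur, and it is within the scatter. There is therefore no basis for expecting a change beyond the scatter. The expected step is a 1.0-fold lower number from compound 3 to compound 4 (0.01 log units; within the scatter), within the scatter. Compound 4 is estimated at 23000 nM in this assay, with a range from 9000 nM to 55000 nM.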

Compound 4, half-maximal inhibitory concentration: 22400 nM
Estimate against measurement, compound 4: 1.0-fold (0.01 log units) above; the range from low to high includes it.
By their numbers in this assay, from the lowest: compounds 1, 2, 4 and 3 (each within the scatter of the next, the first and the last beyond it).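

In this assay, 2-fluorophenyl in place of phenyl at the hydrazone end gives a 1.1-fold lower number from compound 3 to compound 4 (0.02 log units; within the scatter) and so stays within the scatter. Within the data shown here, this is the first measured step on this ring, as the earlier step concerned only the halogenated phenyl groups on the chain carbon bound to the sulfur. It shows that, for this pair, a single fluoro on an aromatic carbon ortho to a large group gives a number that cannot be told apart from that of the unsubstituted phenyl, and no measured evidence offers a reason for this.

The compounds shown leave open whether chlorine, bromine or a methoxy group on this ring would give the same result. They also leave open what an amine or a carboxylic acid there would do in this assay.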